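This account rests on a few compounds, and the source may have more. Where it says the series, first, only, none or still open, it means among the compounds named here.

Of the compounds shown here, three of a shared core have been measured, and a fourth awaits its number. Compound 1 `COc1cc(C)cc(-c2c(-c3ccnc(-c4ccc(C(C)=O)cc4)c3)cnn2CC#N)c1` gives 98% in a functional assay on SF-295 cells (Homo sapiens) for cytotoxicity, read by sulforhodamine B assay, with a stated time of 48 h, tested at 0.001 uM (a higher number here means a weaker effect of the compound at the concentration tested, a lower number a stronger effect), which at this very low concentration means the cells are almost unaffected. Compound 2 `Cc1cc(O)cc(-c2nn(CC#N)cc2-c2ccnc(-c3ccc(Oc4ccccc4)cc3)c2)c1` gives 99% in this assay, and compound 3 `COc1cc(C)cc(-c2nn(CC#N)cc2-c2ccnc(-c3ccc(N(C)C)cc3)c2)c1` gives 93% in this assay. Compound 1 holds the second highest of the three numbers, but its neighbours on either side, compound 2 and compound 3, both lie within the usual scatter of it, so the three cannot be told apart.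

Compound 4 `COc1cc(C)cc(-c2c(-c3ccnc(-c4ccc(N(C)C)cc4)c3)cnn2CC#N)c1` differs from compound 1 in one place: dimethylamino in place of acetyl on an aromatic carbon. Compound 3 already carries the dimethylamino group on an otherwise differently arranged core, and its number sits close to that of compound 1. With every measured value near the top of the scale, no step beyond the scatter is expected in this assay; the expected change is a number 3 percentage points lower from compound 1 to compound 4 (within the scatter). For compound 4 the estimate is 95%, with a likely range from 85% to 103%.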

Compound 4, a percentage reported as activity, at one concentration (the size of the read-out at that concentration, not a potency): 83%
Compound 4: middle estimate off by 12 percentage points, on the high side, and the stated range ends above it.
By their numbers in this assay, from the lowest: compounds 4, 3, 1 and 2 (each within the scatter of the next, the first and the last beyond it).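

Replacing acetyl with dimethylamino, para to a large group on the six-membered aromatic ring, gives a number 15 percentage points lower from compound 1 to compound 4 (beyond the scatter) in this assay, so a change at this position can move the read-out even at this very low concentration. The two groups match in their counts of heavy atoms and hydrogen-bond acceptors, so those counts alone do not separate them, and the step must be tied to the exchange of these particular groups. Nothing available here explains why the number moves.

This single step gives no trend across the position, and a carboxylic acid or a primary amine at the same place could land anywhere relative to compound 1 and compound 4. From the compounds shown here alone, whether the step would hold at higher concentrations also remains open.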